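A few compounds are considered here, and "the series" means these few. Any claim that something is new, unique, unknown or untested is made for them only; others in the source may bear on it.

Measured so far:
compound 1, `O=C(O)CCCCOc1ccc2c(=O)c(-c3ccc(O)cc3)coc2c1`, which gives 5000 nM in an assay (Cricetulus griseus) for inhibition of Monoamine oxidase (Homo sapiens); a higher number here means a weaker inhibitor, a lower number a stronger inhibitor;
compound 2, `CCCCC(Oc1ccc2c(=O)c(-c3ccc(O)cc3)coc2c1)C(=O)OCC`, which in this assay gives only >> 9000 nM.

For compound 2 that figure is a limit of the assay rather than a measured number; it sits at the limit of >> 9000 nM in this assay, at which 1 of the 2 values shown sits. For the measured compounds named here, compound 1 therefore holds the only actual number in this small set, and no step between two measured compounds is available to calibrate a guess. Compound 3, `CC(C)Oc1ccc2c(=O)c(-c3ccc(O)cc3)coc2c1`, is the next step taken from compound 1: the change is isopropyl in place of 4-carboxybutyl on an oxygen on an aromatic ring. Going by the values given here, with no measured step to lean on, the size of the change in this assay can only be estimated; a modest weakening, not far beyond the usual scatter, seems the likeliest outcome. Compound 3 is therefore expected to give 8000 nM, within a range from 2000 nM to 40000 nM. This estimate corresponds to an expected step of a 1.6-fold higher number from compound 1 to compound 3 (0.20 log units; within the scatter).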

Compound 3, half-maximal inhibitory concentration: 200 nM
For compound 3 the middle estimate is 40-fold (1.60 log units) above the measured one; measured number outside the range, below it.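

Replacing 4-carboxybutyl with isopropyl on this oxygen gives a 25-fold lower number from compound 1 to compound 3 (1.40 log units; beyond the scatter) in this assay, which shows that inhibition is sensitive to the group at this position. The shorter, branched isopropyl has no hydrogen-bond donor or acceptor, yet it gives the stronger inhibitor of this pair, so a carboxylic acid at the end of a chain is not required for activity on this core. Nothing shown here explains why the step is so large.

This single change alters chain length, branching and the acid end together, so the compounds shown cannot separate their contributions. On these data alone, it remains open how a plain butyl chain, a shorter carboxymethyl group or a chain ending in an amine would compare with isopropyl.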